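Halogen Shift on the Hydrazone Phenyl of Compound 3

The source may hold more compounds than are shown below. What is called first, only, known or untested is meant among the compounds shown, and "the series" means these compounds.

Compound 1 `Cc1c(C(=O)N/N=C\c2cccc(O)c2O)oc2cccc(O)c12`: 5030 nM
Compound 2 `Cc1c(C(=O)N/N=C\c2cccc(F)c2O)oc2cccc(O)c12`: 8350 nM
Compound 3 `Cc1c(C(=O)N/N=C\c2cc(Cl)ccc2O)oc2cccc(O)c12`: 4160 nM

The three measured compounds share one core and differ only in the aryl ring on the carbon with a double bond to nitrogen. In a functional assay on MGC-803 cells (Homo sapiens) for inhibition, read by MTT assay (on this read-out higher numbers stand for weaker inhibition and lower numbers for stronger inhibition), compound 3 gives 4160 nM, the lowest of the three numbers, yet its neighbours sit close: a 1.2-fold lower number from compound 1 to compound 3 (0.08 log units; within the scatter) and a 2.0-fold lower number from compound 2 to compound 3 (0.30 log units; within the scatter), both within the scatter. Compound 4 `Cc1c(C(=O)N/N=C\c2cccc(Br)c2O)oc2cccc(O)c12` carries 3-bromo-2-hydroxyphenyl in place of 5-chloro-2-hydroxyphenyl on a carbon with a double bond to nitrogen. Within the data shown here, no single measured step matches this change. The nearest are a 2.0-fold lower number from compound 2 to compound 3 (0.30 log units; within the scatter), which exchanged a 3-fluoro-2-hydroxyphenyl for the 5-chloro-2-hydroxyphenyl, and a 1.7-fold higher number from compound 1 to compound 2 (0.22 log units; within the scatter), which put fluoro in place of hydroxy on an aromatic carbon; neither left the scatter. Returning to a 3-halo-2-hydroxyphenyl, now with bromine, is therefore expected to give no step beyond the scatter in this assay, with a slight lean toward a higher number. Compound 4 is expected at 6000 nM (range 2500 nM to 15000 nM). That corresponds to an estimated 1.4-fold higher number from compound 3 to compound 4 (0.16 log units; within the scatter).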

Compound 4, half-maximal inhibitory concentration: 14200 nM
Estimate against measurement, compound 4: 2.4-fold (0.37 log units) below; measured number inside the range.
By their numbers in this assay, from the lowest: compounds 3, 1, 2 and 4 (each within the scatter of the next, the first and the last beyond it).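

In this assay, among these compounds, the aryl ring on the carbon with a double bond to nitrogen now shows steps beyond the scatter, which no step among the first three compounds did: 3-bromo-2-hydroxyphenyl in place of 5-chloro-2-hydroxyphenyl gives a 3.4-fold higher number from compound 3 to compound 4 (0.53 log units; beyond the scatter) and bromo in place of hydroxy gives a 2.8-fold higher number from compound 1 to compound 4 (0.45 log units; beyond the scatter). Bromo in place of fluoro, by contrast, gives a 1.7-fold higher number from compound 2 to compound 4 (0.23 log units; within the scatter), so compound 4 cannot be separated from compound 2 and the change shows up only against compound 1 and compound 3. Nothing available explains these steps.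

Still open, as far as these compounds go, is whether the step from compound 3 follows the change of halogen or the change of its place on the ring, which a 5-bromo-2-hydroxyphenyl or a 3-chloro-2-hydroxyphenyl would separate. Also open, from the compounds shown here alone, is how a 3-methoxy-2-hydroxyphenyl or a 3-amino-2-hydroxyphenyl would read here.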